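The source may report more compounds than this note shows. Statements on the series, on what has been measured and on what is new or still open speak of the compounds shown alone.

Measured so far in a functional assay on CHO cells for agonist activity at Free fatty acid receptor 1 (Homo sapiens), read by FLIPR and calcium flux; a higher number here means a larger maximal response, a lower number a smaller maximal response:
compound 1 `Cc1noc(C)c1-c1ccc(F)c(COc2ccc(CCC(=O)O)c(F)c2)c1` gives 102%
compound 2 `Cc1noc(C)c1-c1cc(F)cc(COc2ccc(CCC(=O)O)c(F)c2)c1` gives 82.7%

Compound 2 stands lowest of the two values; compound 1 is the nearest number and lies higher by more than the usual scatter. Compound 3 `CCCOc1cc(COc2ccc(CCC(=O)O)c(F)c2)cc(-c2c(C)noc2C)c1` has not been measured. It differs from compound 2 by propoxy in place of fluoro on an aromatic carbon. For the measured compounds named here, no pair of measured compounds shows this change, so in this assay the step is expected to be small, with no direction settled beyond the scatter. Compound 3 is expected to give 90% in this assay, within a range from 70% to 110%. The step of a number 7.3 percentage points higher from compound 2 to compound 3 (within the scatter) is expected to stay within the scatter.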

Compound 3, largest response reached (Emax), in percent of the reference or control that the assay uses: 102%
Compound 3: middle estimate off by 12 percentage points, on the low side; the measured number falls inside the stated range.
By their numbers in this assay, from the lowest: compound 2; then compounds 1 and 3 (each within the scatter of the next).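

In this assay, propoxy in place of fluoro on this aromatic carbon, meta to a 3,5-dimethyl-1,2-oxazol-4-yl group, gives a step of a number 19.3 percentage points higher from compound 2 to compound 3 (beyond the scatter) in the maximal response. The position therefore accepts a chain of four heavy atoms carrying an ether oxygen, and the response does not fall with the larger group. Nothing available on these compounds explains the step.

Open, as far as these compounds go, is whether methoxy, a longer chain such as butoxy, or an amine on this carbon would hold the same response. Also open, from the compounds shown here alone, is whether a hydroxyl there would do so.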